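Aldehyde versus acylhydrazone: the methoxy-to-trifluoromethyl step

This account rests on a few compounds, and the source may have more. Where it says the series, first, only, none or still open, it means among the compounds named here.

Compound 1 `CCCCc1ccc2[nH]c(-c3ccc(OC)cc3)c(C=O)c2c1` carries the aldehyde; in a functional assay on MDA-MB-231 cells (Homo sapiens) for antiproliferative activity, with a stated time of 4 days (on this read-out lower numbers stand for stronger inhibition and higher numbers for weaker inhibition), compound 1 gives 6.7 nM. Compound 2 `CCCCc1ccc2[nH]c(-c3ccc(C(F)(F)F)cc3)c(C=O)c2c1` differs only by trifluoromethyl in place of methoxy on an aromatic carbon; in this assay compound 2 gives 33 nM, so the step is a 4.9-fold higher number from compound 1 to compound 2 (0.69 log units; beyond the scatter). Compound 3 `CCCCc1ccc2[nH]c(-c3ccc(OC)cc3)c(/C=N/NC(=O)c3ccc(OC)cc3)c2c1` keeps the methoxy group but replaces the aldehyde with an acylhydrazone; the difference between the two cores is not broken down here. In this assay, within the data shown here, compound 3 gives 61 nM, the highest of the three numbers measured so far, though against compound 2 the gap lies within the scatter.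

Compound 4 `CCCCc1ccc2[nH]c(-c3ccc(C(F)(F)F)cc3)c(/C=N/NC(=O)c3ccc(OC)cc3)c2c1` has not been measured. It differs from compound 3 by trifluoromethyl in place of methoxy on an aromatic carbon, which is the same change as made from compound 1 to compound 2, at the same place on the ring. Among the measured compounds shown here, the expected step is therefore a 4.1-fold higher number from compound 3 to compound 4 (0.61 log units; beyond the scatter), resting on a 4.9-fold higher number from compound 1 to compound 2 (0.69 log units; beyond the scatter) as the only precedent, tempered slightly because compound 3 already starts from 61 nM on a different core. Compound 4 is accordingly estimated at 250 nM, with a plausible range from 80 nM to 800 nM.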

Compound 4, half-maximal inhibitory concentration: 284 nM
For compound 4 the middle estimate is 1.1-fold (0.06 log units) below the measured one; measured number inside the range.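

On the acylhydrazone core, trifluoromethyl in place of methoxy gives a 4.7-fold higher number from compound 3 to compound 4 (0.67 log units; beyond the scatter) in this assay. The change therefore carries from the aldehyde core to the acylhydrazone core with no difference in size that can be told apart from the scatter: the same change on two cores in this assay, a 4.9-fold higher number (0.69 log units; beyond the scatter) from compound 1 to compound 2 and a 4.7-fold higher number (0.67 log units; beyond the scatter) from compound 3 to compound 4, 1.1-fold (0.02 log units) apart, within the scatter of two such steps. Among these compounds, this rests on only two matched pairs, so it shows agreement for this one change on these two cores, but it does not establish that the step would hold on any other core or for any other replacement, and it does not explain why the number rises.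

The compounds shown leave open how an amine, a carboxylic acid or a nitrile in place of the methoxy group on the same aromatic carbon would compare on either core. On these data alone, it also remains open whether the step would keep its size with a longer chain in place of butyl on the shared core.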